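Pyridyl triazolyl alcohols: Vero cytotoxicity working notes

The source may hold more compounds than are shown below. What is called first, only, known or untested is meant among the compounds shown, and "the series" means these compounds.

Compound 1 `OC1(c2nnc(-c3ccncc3)[nH]2)CCCCC1` and compound 2 `OC1(c2nnc(-c3cccnc3)[nH]2)CCCCC1` share one core and differ by pyridin-3-yl in place of pyridin-4-yl on an aromatic carbon. In an ADME assay on Vero cells (Chlorocebus sabaeus) for cytotoxicity, read by MTT assay, with a stated time of 72 h (on this read-out higher numbers stand for lower toxicity in this test and lower numbers for higher toxicity in this test), compound 1 gives 412 ug/mL, and compound 2 gives 397 ug/mL; the step is a 1.0-fold lower number from compound 1 to compound 2 (0.02 log units; within the scatter). Compound 3 `OC(c1nnc(-c2ccncc2)[nH]1)C1CC=CCC1` has another core; the difference between the two cores is not broken down here. In this assay compound 3 gives 388 ug/mL, close to the numbers of compound 1 and compound 2. Compound 4 `OC(c1nnc(-c2cccnc2)[nH]1)C1CC=CCC1` is not yet measured and differs from compound 3 by pyridin-3-yl in place of pyridin-4-yl on an aromatic carbon. Around the place, the ring atom bears a group of 7 heavy atoms in one pair and of 8 heavy atoms in the other, so this is the same kind of change. In this assay the expected step is a 1.0-fold lower number from compound 3 to compound 4 (0.00 log units; within the scatter), because a 1.0-fold lower number from compound 1 to compound 2 (0.02 log units; within the scatter) stayed within the scatter. Compound 4 is therefore expected to give 385 ug/mL, with a likely range from 250 ug/mL to 600 ug/mL.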

Compound 4, half-maximal cytotoxic concentration: 371 ug/mL
Estimate against measurement, compound 4: 1.0-fold (0.02 log units) above; measured number inside the range.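

In this assay, the step on the core of compound 3 reads a 1.0-fold lower number from compound 3 to compound 4 (0.02 log units; within the scatter), and it matches the step on the core of compound 1: the same change on two cores in this assay, a 1.0-fold lower number (0.02 log units; within the scatter) from compound 1 to compound 2 and a 1.0-fold lower number (0.02 log units; within the scatter) from compound 3 to compound 4, 1.0-fold (0.00 log units) apart, within the scatter of two such steps. On these two cores, then, pyridin-3-yl in place of pyridin-4-yl carries over as a step within the scatter. Among the compounds shown here, this shows only that the change stays within the scatter in both pairs; it does not show that the same would hold on a further core or in another read-out.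

The compounds shown leave open whether any other group at this place would move the number. Pyridin-2-yl, or a phenyl ring carrying an amine or a carboxylic acid, would test that on both cores.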